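The compounds below may be only part of what the source reports. "The series", "measured", "known", "first", "only" and "open" are said of these compounds alone.

Measured compounds:
compound 1 `Oc1cccc(-c2cc(-c3ccc(Cl)cc3)nc(-c3ccccn3)c2)c1`, 14000 nM
compound 2 `Oc1ccc(-c2cc(-c3ccc(Cl)cc3)nc(-c3ccccn3)c2)cc1`, 27200 nM
compound 3 `Oc1ccc(-c2cc(-c3ccccc3)nc(-c3cccc(Cl)c3)c2)cc1`, 2820 nM

All values come from an ADME assay on HEK293 cells (Homo sapiens) for cytotoxicity, read by CCK-8 assay and cell counting, with a stated time of 2 days; on this read-out higher numbers stand for weaker inhibition and lower numbers for stronger inhibition. Compound 3 gives a lower number than compound 1 and than compound 2, and both gaps lie beyond the scatter. Compounds 1 and 2 share one core and differ in one place: 3-hydroxyphenyl in place of 4-hydroxyphenyl on an aromatic carbon. That change gave a 1.9-fold lower number from compound 2 to compound 1 (0.29 log units; within the scatter), a step within the scatter, so the two values show no ordered difference. The difference between the core of compound 2 and the core of compound 3 is not broken down here.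

Compound 4 `Oc1cccc(-c2cc(-c3ccccc3)nc(-c3cccc(Cl)c3)c2)c1` has not been measured in this assay. It relates to compound 3 as compound 1 relates to compound 2: 3-hydroxyphenyl in place of 4-hydroxyphenyl on an aromatic carbon. The place is not the same word for word: in compound 4 it is meta to a 3-chlorophenyl group and meta to a phenyl group, whereas in compound 1 it is meta to a 4-chlorophenyl group and meta to a pyridin-2-yl group, so this is the same kind of change rather than the same change. The step from compound 3 to compound 4 is expected to be a 1.4-fold lower number from compound 3 to compound 4 (0.15 log units; within the scatter), resting on the earlier step of a 1.9-fold lower number from compound 2 to compound 1 (0.29 log units; within the scatter), with its direction uncertain because a 1.9-fold lower number from compound 2 to compound 1 (0.29 log units; within the scatter) lies within the scatter. Compound 4 is therefore estimated at 2000 nM, expected to fall between 800 nM and 5500 nM.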

Compound 4, half-maximal inhibitory concentration: 3120 nM
Compound 4: middle estimate off by 1.6-fold (0.19 log units), on the low side, within the range that was stated.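

In this assay, 3-hydroxyphenyl in place of 4-hydroxyphenyl gives a 1.1-fold higher number from compound 3 to compound 4 (0.04 log units; within the scatter), so on this core as well the two values show no ordered difference. This shows that the change carries from one core to the other without a measurable difference between the two steps: the same change on two cores in this assay, a 1.9-fold lower number (0.29 log units; within the scatter) from compound 2 to compound 1 and a 1.1-fold higher number (0.04 log units; within the scatter) from compound 3 to compound 4, 2.1-fold (0.33 log units) apart, within the scatter of two such steps. It does not give the change a direction on either core, and two cores do not show that the same would hold on a third.

The compounds shown carry only a hydroxyl on this phenyl group, so the effect of a methoxy group, an amine or a carboxylic acid in its stead remains open. Also open, going by these compounds, is how the difference between the core of compound 2 and the core of compound 3 divides between the pyridin-2-yl group and the chlorine, since these cores differ in more than one place.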